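Adding a Chloro Group to the Phenyl of Compound 3

This account rests on a few compounds, and the source may have more. Where it says the series, first, only, none or still open, it means among the compounds named here.

The three measured compounds in an assay on microsomes from brain for inhibition of Fatty-acid amide hydrolase 1 (Rattus norvegicus), read by fluorescence and HPLC, with a stated time of 60 min; on this read-out lower numbers stand for stronger inhibition and higher numbers for weaker inhibition:
compound 1 `CCCCCCCCc1ccc(OCC(=O)Cn2nnc(-c3ccccc3)n2)cc1` gives 24 nM
compound 2 `CCCCCCCCc1ccc(OCC(=O)Cn2nnnc2SC)cc1` gives 22 nM
compound 3 `CCCCCCCCc1ccc(OCC(=O)Cn2nnnc2-c2ccccc2)cc1` gives 71 nM

Compound 3 stands highest of the three numbers in this assay. Its nearest neighbour is compound 1 with 24 nM, and the furthest is compound 2 with 22 nM; both gaps lie beyond the scatter. Going by the values given here, the one step between compounds that differ in a single place is a 3.2-fold higher number from compound 2 to compound 3 (0.51 log units; beyond the scatter), a modest rise, brought by phenyl in place of methylsulfanyl on an aromatic carbon.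

Compound 4 `CCCCCCCCc1ccc(OCC(=O)Cn2nnnc2-c2cccc(Cl)c2)cc1` differs from compound 3 by chloro in place of hydrogen on an aromatic carbon. Among the compounds with values here, no measured step bears directly on this change: the only single-place step, a 3.2-fold higher number from compound 2 to compound 3 (0.51 log units; beyond the scatter), concerns exchange of the whole group on that aromatic carbon, not a substituent on the phenyl ring itself. Compound 1 and compound 3 both carry an unsubstituted phenyl, so they give no guidance on a chloro either. With nothing in the data pointing one way or the other, compound 4 is expected to stay close to compound 3 in this assay, with a step of a 1.2-fold lower number from compound 3 to compound 4 (0.07 log units; within the scatter) not beyond the scatter. Compound 4 is therefore estimated at 60 nM, within a range from 25 nM to 150 nM.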

Compound 4, half-maximal inhibitory concentration: 360 nM
Beside the measured number, compound 4's estimate is 6.0-fold (0.78 log units) below it; the measured number lies above the stated range.
By their numbers in this assay, from the lowest: compounds 2 and 1 (each within the scatter of the next); then compound 3; then compound 4.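

In this assay, the phenyl of compound 3 turns out not to be a place where a small addition passes unnoticed: a single chloro on an aromatic carbon, meta to a large group, gives a 5.1-fold higher number from compound 3 to compound 4 (0.71 log units; beyond the scatter). Measured against the methylsulfanyl group, the exchange for 3-chlorophenyl amounts to a 16-fold higher number from compound 2 to compound 4 (1.21 log units; beyond the scatter), so the rise already seen with phenyl, a 3.2-fold higher number from compound 2 to compound 3 (0.51 log units; beyond the scatter), goes further once this one heavy atom is added, and the step from methylsulfanyl reaches the large range. The compounds shown offer no measurement that would account for this rise.

They leave open whether the rise belongs to chloro itself or would come with any group on this carbon, such as fluoro, methoxy or a carboxylic acid, and whether chloro on another carbon of the phenyl ring would give a step of the same size. Going by these compounds, it also remains open whether the same phenyl to 3-chlorophenyl change would raise the number in the same way on compound 1, where the phenyl is attached at a different place on the shared core.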